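Taking the phenoxy group off compound 2

A few compounds are considered here, and "the series" means these few. Any claim that something is new, unique, unknown or untested is made for them only; others in the source may bear on it.

Within the data shown here, in a functional assay on HL-60 cells (Homo sapiens) for inhibition, read by resazurin assay, with a stated time of 72 h (on this read-out higher numbers stand for weaker inhibition and lower numbers for stronger inhibition), compound 2 (`CCOc1ccc(C2C(Oc3ccccc3)C(=O)N2c2cc(OC)c(OC)c(OC)c2)cc1`) gives 494 nM and stands highest of the two numbers so far, with compound 1 (`CCOc1ccc(C2C(C3CC3)C(=O)N2c2cc(OC)c(OC)c(OC)c2)cc1`) nearest at 201 nM on the lower side. Compound 3 (`CCOc1ccc(C2CC(=O)N2c2cc(OC)c(OC)c(OC)c2)cc1`) has hydrogen in place of phenoxy on a saturated ring carbon. Among the measured compounds shown here, the only measured step at this place, a 2.5-fold higher number from compound 1 to compound 2 (0.39 log units; beyond the scatter) with phenoxy in place of cyclopropyl, is modest. For the measured compounds named here, no measured compound carries hydrogen there, so the direction stays open and no step beyond the scatter is expected in this assay here. The estimated step is a 1.2-fold higher number from compound 2 to compound 3 (0.08 log units; within the scatter) on this reading. Compound 3 is estimated at 600 nM with an expected range of 180 nM to 2000 nM in this series.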

Compound 3, half-maximal inhibitory concentration: 88 nM
Beside the measured number, compound 3's estimate is 6.8-fold (0.83 log units) above it; the measured number lies below the stated range.
By their numbers in this assay, from the lowest: compound 3; then compound 1; then compound 2.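

In this assay, hydrogen on this saturated ring carbon gives a 5.6-fold lower number from compound 2 to compound 3 (0.75 log units; beyond the scatter) and also a 2.3-fold lower number from compound 1 to compound 3 (0.36 log units; beyond the scatter), so both larger groups tested here, phenoxy and cyclopropyl, sit above the unsubstituted compound. Of the three compounds, compound 3 therefore now marks the lowest number at this position. No evidence on hand accounts for this order.

From the compounds shown here alone, whether a methyl group, a hydroxyl or an amine on this ring carbon would stay near compound 3 or move towards compound 1 remains open.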